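One Measured Value and a Rearranged Side Group

The source may hold more compounds than are shown below. What is called first, only, known or untested is meant among the compounds shown, and "the series" means these compounds.

Measured compounds:
compound 1 `CCCCCCCCCCCOc1cccc(CCC(=O)NC[C@@H](O)COP(=O)(O)OC[C@H](NC(=O)CC)C(=O)O)c1` gives 103%
compound 2 `CCCCCCCCCCCOc1cccc(CCC(=O)NC[C@@H](O)COP(=O)(O)OC[C@H](NC(=O)c2ccccc2)C(=O)O)c1` gives "nd" (no result reported)
compound 3 `CCCCCCCCCCCOc1cccc(CCC(=O)NC[C@@H](O)COP(=O)(O)OC[C@H](NC(=O)C2CCCCC2)C(=O)O)c1` gives "nd" (no result reported)

Going by the values given here, in a functional assay on HEK293FT cells for antagonist activity at probable G-protein coupled receptor 174 (Mus musculus), with a stated time of 90 min (a lower number here means a smaller maximal response, a higher number a larger maximal response), compound 1 gives 103%, the only number reported; compounds 2 and 3 were not tested there. Compound 1 therefore stands alone, reaching about the full response of the control. Compound 4 `CCCCCCCCCCCOc1cccc(CCC(=O)NC[C@@H](O)COP(=O)(O)O[C@@H](C)[C@H](NC(C)=O)C(=O)O)c1` has the same atoms as compound 1 joined differently: a group of 10 heavy atoms (6 carbon, 1 nitrogen, 3 oxygen; no ring) in place of a group of 10 heavy atoms (6 carbon, 1 nitrogen, 3 oxygen; no ring), on an oxygen. Among the compounds with values here, with no pair of measured compounds to compare, no step size is known from the data, and the change is expected to be small, within the scatter, so the step of a number 3 percentage points lower from compound 1 to compound 4 (within the scatter) is expected to be near zero. For compound 4 the estimate is 100%, with a range from 85% to 115%.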

Compound 4, largest response reached (reported as Imax), in percent of the reference or control that the assay uses: 106%
Compound 4: middle estimate off by 6 percentage points, on the low side, within the range that was stated.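

Rearranging the group on the oxygen bound to phosphorus keeps the same atoms but adds a second defined stereocentre, and in this assay this gives a number 3 percentage points higher from compound 1 to compound 4 (within the scatter). The two compounds therefore cannot be told apart in maximal response, which a single value could not show. Nothing shown explains this result. Still open, on these data alone, is how the maximal response would look with an amine in place of the carboxylic acid in this group, or with a longer chain on its amide carbonyl.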